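A few compounds are considered here, and "the series" means these few. Any claim that something is new, unique, unknown or untested is made for them only; others in the source may bear on it.

Of the compounds shown here, two have so far been measured in a functional assay on MDA-MB-231 cells (Homo sapiens) for inhibition, read by sulforhodamine B assay, with a stated time of 48 h; on this read-out higher numbers stand for weaker inhibition of growth and lower numbers for stronger inhibition of growth. Compound 1 `Cc1cc(O)cc(-c2nn(CC#N)cc2-c2ccnc(-c3ccc(Oc4ccccc4)cc3)c2)c1` gives 2280 nM in this assay, and compound 2 `COc1cc(C)cc(-c2nn(CC#N)cc2-c2ccnc(-c3ccc(N(C)C)cc3)c2)c1` gives 1090 nM, the lowest of the two numbers; the gap from compound 1 to compound 2 lies beyond the scatter of repeated measurements. Going by the values given here, the two compounds differ in more than one place, so their values show only that compound 2 sits lower.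

Compound 3 `Cc1cc(O)cc(-c2nn(CC#N)cc2-c2ccnc(-c3ccc(N(C)C)cc3)c2)c1` differs from compound 2 in a single place: hydrogen in place of methyl on an oxygen on an aromatic ring. No change of this kind between measured compounds is available to set a scale. Compound 1 also carries the hydroxy group, but together with a phenoxy group rather than the dimethylamino group, so its value gives no clean guide. The step of a 1.2-fold lower number from compound 2 to compound 3 (0.08 log units; within the scatter) is expected to be small and within the scatter. Compound 3 is expected to give 900 nM, with a range from 350 nM to 2500 nM.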

Compound 3, concentration for 50% growth inhibition: 2940 nM
Compound 3: middle estimate off by 3.3-fold (0.51 log units), on the low side; the whole stated range lies below it.
By their numbers in this assay, from the lowest: compound 2; then compounds 1 and 3 (each within the scatter of the next).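

In this assay, going by these compounds alone, the group on this oxygen counts: with dimethylamino held in place, hydroxy in place of methoxy gives a 2.7-fold higher number from compound 2 to compound 3 (0.43 log units; beyond the scatter), the first measured step at this position. With the hydroxy group held in place, dimethylamino in place of phenoxy on an aromatic carbon gives a 1.3-fold higher number from compound 1 to compound 3 (0.11 log units; within the scatter), so these two groups are not separated by this read-out in that setting. Nothing measured here accounts for either step.

The compounds shown leave open whether a longer ether such as ethoxy, or an amine or a fluorine atom on that aromatic carbon, would stay near the methoxy compound or near the hydroxy compound. They also leave open whether methoxy in place of hydroxy would give a similar step when phenoxy stands in place of dimethylamino.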